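Swapping the aryl group on a diaminotriazine spiro series

A few compounds are considered here, and "the series" means these few. Any claim that something is new, unique, unknown or untested is made for them only; others in the source may bear on it.

Measured compounds:
compound 1 `NC1=NC2(CCSCC2)N(OCCCOc2ccc(Cl)c(Cl)c2)C(N)=N1` — 70 nM
compound 2 `Cc1cc(C)cc(OCCCON2C(N)=NC(N)=NC23CCOCC3)c1` — 680 nM

In a functional assay on HepG2 cells (Homo sapiens) for antiproliferative activity, read by MTT assay, with a stated time of 72 h (on this read-out lower numbers stand for stronger inhibition and higher numbers for weaker inhibition), compound 1 gives 70 nM, the lowest of the two numbers shown; compound 2 gives 680 nM, a gap beyond the scatter, though the two structures differ in more than one place. Compound 3 `COc1ccc(OCCCON2C(N)=NC(N)=NC23CCSCC3)cc1` has not yet been measured. It differs from compound 1 in one place: 4-methoxyphenyl in place of 3,4-dichlorophenyl on an oxygen on a saturated carbon. Going by the values given here, with no single-change step in hand, a modest loss is expected for compound 3, a 3.6-fold higher number from compound 1 to compound 3 (0.55 log units; beyond the scatter), since the halogenated aryl carries the strongest value, compound 1 at 70 nM. Compound 3 is estimated at 250 nM, range 80 nM to 800 nM.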

Compound 3, half-maximal inhibitory concentration: 880 nM
Compound 3: middle estimate off by 3.5-fold (0.55 log units), on the low side; the measured number lies above the stated range.
By their numbers in this assay, from the lowest: compound 1; then compounds 2 and 3 (each within the scatter of the next).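

In this assay, going by these compounds alone, 4-methoxyphenyl in place of 3,4-dichlorophenyl gives a 13-fold higher number from compound 1 to compound 3 (1.10 log units; beyond the scatter), the first single-change reading at this place. It shows that, with the rest of compound 1 held fixed, the aryl group on the oxygen alone can produce a large step. Nothing available gives a reason for this step. The compounds shown leave open how 4-chlorophenyl or unsubstituted phenyl would read at this place. They also leave open whether the same change would give a similar step on the core of compound 2.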